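The source may hold more compounds than are shown below. What is called first, only, known or untested is meant among the compounds shown, and "the series" means these compounds.

In an ADME assay on WI-38 cells (Homo sapiens) for cytotoxicity, read by MTT assay, with a stated time of 72 h (a higher number here means a weaker inhibitor, a lower number a stronger inhibitor), three compounds sharing one core have been measured. Compound 1 `O=C(CCc1cccc2c1B(O)OC2)Nc1cccc(Br)c1` gives 20000 nM, compound 2 `O=C(CCc1cccc2c1B(O)OC2)Nc1cccc(-c2ccccc2)c1` gives 12000 nM, and compound 3 `COc1cc(OC)cc(-c2cccc(NC(=O)CCc3cccc4c3B(O)OC4)c2)c1` gives 1700 nM, the lowest of the three numbers. The next structure, compound 4 `CSc1ccc(-c2cccc(NC(=O)CCc3cccc4c3B(O)OC4)c2)cc1`, departs from compound 3 in one place: 4-(methylsulfanyl)phenyl in place of 3,5-dimethoxyphenyl on an aromatic carbon.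

Within the data shown here, three measured steps bear on this change. Phenyl in place of bromo gave a 1.7-fold lower number from compound 1 to compound 2 (0.22 log units; within the scatter). By contrast, 3,5-dimethoxyphenyl in place of bromo gave a 12-fold lower number from compound 1 to compound 3 (1.07 log units; beyond the scatter), and 3,5-dimethoxyphenyl in place of phenyl gave a 7.1-fold lower number from compound 2 to compound 3 (0.85 log units; beyond the scatter). Among these compounds, the lowest number therefore comes with the 3,5-dimethoxyphenyl group, which compound 4 gives up. Among the measured compounds shown here, no measured compound carries 4-(methylsulfanyl)phenyl, so the size of the step remains uncertain. Part of the step from phenyl to 3,5-dimethoxyphenyl is expected to be lost, moving the number upward in this assay. The expected step is a 2.9-fold higher number from compound 3 to compound 4 (0.47 log units; beyond the scatter). Compound 4 is estimated at 5000 nM, within an expected range of 1700 nM to 15000 nM.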

Compound 4, half-maximal inhibitory concentration: 3800 nM
Beside the measured number, compound 4's estimate is 1.3-fold (0.12 log units) above it; the measured number falls inside the stated range.
By their numbers in this assay, from the lowest: compound 3; then compound 4; then compounds 2 and 1 (each within the scatter of the next).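

At this aromatic carbon, meta to a large group, adding a methylsulfanyl group to the phenyl group is enough to move the number beyond the scatter (a 3.2-fold lower number from compound 2 to compound 4 (0.50 log units; beyond the scatter)), so the lower numbers are not confined to the 3,5-dimethoxyphenyl group. Measured against the bromo starting point, 4-(methylsulfanyl)phenyl also gives a clear change (a 5.3-fold lower number from compound 1 to compound 4 (0.72 log units; beyond the scatter)), yet it does not match the 3,5-dimethoxyphenyl group (a 2.2-fold higher number from compound 3 to compound 4 (0.35 log units; beyond the scatter)). Nothing available explains the sizes of these steps.

The two substituted phenyl groups differ in both the substituents they carry and where those substituents sit, so the compounds shown cannot separate these features. From the compounds shown here alone, it also remains open how a single methoxy group, an amine or a carboxylic acid on the phenyl group would move the number.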